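Swapping Bromo for Trifluoromethyl on a Weak Analogue

The compounds below may be only part of what the source reports. "The series", "measured", "known", "first", "only" and "open" are said of these compounds alone.

Of the compounds shown here, three sharing one core have been tested in a functional assay on WM 266-4 cells (Homo sapiens) for antiproliferative activity, read by MTT assay, with a stated time of 48 h; on this read-out lower numbers stand for stronger inhibition and higher numbers for weaker inhibition. Compound 2 `Fc1ccc(C2=NN(c3nc(-c4ccc(Br)cc4)cs3)C(c3cccs3)C2)cc1` gives 220 nM, compound 1 `COc1ccc(C2=NN(c3nc(-c4ccc(C(F)(F)F)cc4)cs3)C(c3cccs3)C2)cc1` gives 8110 nM, and compound 3 `Cc1ccc(C2=NN(c3nc(-c4ccc(Br)cc4)cs3)C(c3cccs3)C2)cc1` gives 18400 nM, the highest of the three numbers. Among the measured compounds shown here, the only single-point step among them is an 84-fold higher number from compound 2 to compound 3 (1.92 log units; beyond the scatter), which concerns the methyl and fluoro groups and not the position changed here.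

Compound 4 `Cc1ccc(C2=NN(c3nc(-c4ccc(C(F)(F)F)cc4)cs3)C(c3cccs3)C2)cc1` keeps the methyl of compound 3 and differs from it only by trifluoromethyl in place of bromo on an aromatic carbon. For the measured compounds named here, no measured step covers a change of bromo to trifluoromethyl, so the expectation rests on little. Compound 1 also carries trifluoromethyl and gives 8110 nM, but it differs from compound 3 in two places, so its value only shows that a trifluoromethyl analogue can land in a similar weak range. A step of a 1.2-fold lower number from compound 3 to compound 4 (0.09 log units; within the scatter) is therefore expected, within the ordinary scatter. For compound 4 in this assay the estimate is 15000 nM, with a likely range from 4000 nM to 50000 nM.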

Compound 4, half-maximal inhibitory concentration: 2110 nM
Estimate against measurement, compound 4: 7.1-fold (0.85 log units) above; the measured number lies below the stated range.
By their numbers in this assay, from the lowest: compound 2; then compound 4; then compound 1; then compound 3.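

In this assay, among the compounds shown here, the change from 4-bromophenyl to 4-(trifluoromethyl)phenyl gives an 8.7-fold lower number from compound 3 to compound 4 (0.94 log units; beyond the scatter), the first direct evidence that the group at this position affects the result, although it comes from a single matched pair carrying methyl at the other end of the molecule. With trifluoromethyl held constant, methyl in place of methoxy gives a 3.8-fold lower number from compound 1 to compound 4 (0.58 log units; beyond the scatter), showing that the group at the other end still matters when trifluoromethyl occupies this position. Nothing available explains why either change shifts the number.

As far as these compounds go, it remains open whether trifluoromethyl would also lower the number if it replaced bromo in compound 2, which carries fluoro instead of methyl. How a nitrile, an amine or a carboxylic acid would behave at this position is also unresolved.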